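Compound 3 compared with compound 2

The source may report more compounds than this note shows. Statements on the series, on what has been measured and on what is new or still open speak of the compounds shown alone.

Compound 1 `O=c1[nH]cc(S(=O)(=O)Nc2ccccc2-c2cn(-c3cccc(Cl)c3)nn2)c(=O)[nH]1`: > 100000 nM
Compound 2 `Cc1ccccc1-n1cc(-c2cccc(NS(=O)(=O)c3c[nH]c(=O)[nH]c3=O)c2)nn1`: 15300 nM

Among the measured compounds shown here, in an ADME assay on L02 cells (Homo sapiens) for cytotoxicity, read by MTT assay, with a stated time of 24 h (a higher number here means that more compound is tolerated, a lower number that less compound is tolerated), compound 2 gives 15300 nM, the only actual number available so far. Compound 1 is recorded at > 100000 nM, which is a limit of the assay and not a number.

Compound 3 `O=c1[nH]cc(S(=O)(=O)Nc2cccc(-c3cn(-c4cccc(Cl)c4)nn3)c2)c(=O)[nH]1` has not yet been measured and is compared here with compound 2. The change 3-chlorophenyl in place of 2-methylphenyl on an aromatic nitrogen puts 3-chlorophenyl in place of 2-methylphenyl on an aromatic nitrogen. For the measured compounds named here, no measured pair of compounds isolates this exchange, and the size of the step cannot be read directly from the data.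

A modest rise in this assay is expected, possibly not far beyond the usual scatter. This expectation starts from compound 2 at 15300 nM and leans upward only cautiously. Going by the values given here, the only other measured compound, compound 1, sits at the limit > 100000 nM and gives no number to scale from. The expected change is a 1.6-fold higher number from compound 2 to compound 3 (0.21 log units; within the scatter). For compound 3 the estimated value is 25000 nM, with an expected range of 9000 nM to 80000 nM.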

Compound 3, half-maximal cytotoxic concentration: 8330 nM
Estimate against measurement, compound 3: 3.0-fold (0.48 log units) above; the measured number lies below the stated range.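

In this assay, putting 3-chlorophenyl in place of 2-methylphenyl on an aromatic nitrogen of the five-membered aromatic ring with 3 nitrogen gives a 1.8-fold lower number from compound 2 to compound 3 (0.26 log units; within the scatter). Among the compounds shown here, this is the first exchange at this position that can be read as a number, and it shows that these two groups, each with 7 heavy atoms and one six-membered aromatic ring of carbon only, cannot be told apart in this assay: the chlorine at one ring place and the methyl at another leave the tolerated concentration within the usual scatter. Compound 1 remains a limit of the assay and not a number, and the steps that touch it cannot be read: the limit of > 100000 nM in this assay, at which 1 of the 3 values shown sits.

The compounds shown carry only a substituted phenyl at this nitrogen, so it remains open whether a group of another kind there, such as a carboxylic acid or a longer alkyl chain, would move the value beyond the scatter. On these data alone, it also remains open whether a plain phenyl would differ from either of these two groups, and so whether the chlorine or the methyl matters on its own.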